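This account rests on a few compounds, and the source may have more. Where it says the series, first, only, none or still open, it means among the compounds named here.

Measured so far:
- compound 2, `COc1cc(C(=O)O)ccc1OCc1nc(C)c(C)nc1C`: in a functional assay on ECV-304 cells (Homo sapiens), read by MTT assay, with stated times of 24 h and 12 h, tested at 12.5 uM (on this read-out higher numbers stand for a stronger effect at the one concentration tested and lower numbers for a weaker effect), compound 2 gives 15.1%
- compound 1, `COC(=O)c1ccc(OCc2nc(C)c(C)nc2C)c(OC)c1`: in this assay compound 1 gives 14.9%

Compound 2 stands alongside compound 1, the two values within the scatter of each other. Compound 3, `C=CCc1ccc(OCc2nc(C)c(C)nc2C)c(OC)c1`, differs from compound 2 by allyl in place of carboxy on an aromatic carbon. For the measured compounds named here, the only measured step, a number 0.2 percentage points higher from compound 1 to compound 2 (within the scatter), touched the same carboxy group and stayed within the scatter; no measured step shows what replacing the whole carboxy does. No shift beyond the scatter is therefore expected in this assay. Compound 3 is estimated at 15%, between 5% and 30%. The expected step is a number 0.1 percentage points lower from compound 2 to compound 3 (within the scatter).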

Compound 3, a percentage reported as activity, at one concentration (the size of the read-out at that concentration, not a potency): 22%
For compound 3 the middle estimate is 7 percentage points below the measured one; the range from low to high includes it.
By their numbers in this assay, from the lowest: compounds 1, 2 and 3 (each within the scatter of the next).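

Putting allyl in place of carboxy on this aromatic carbon gives a number 6.9 percentage points higher from compound 2 to compound 3 (within the scatter) in this assay, and putting it in place of methoxycarbonyl gives a number 7.1 percentage points higher from compound 1 to compound 3 (within the scatter). So at this position, a chain of carbon only, with no hydrogen-bond donors or acceptors, reads the same within the scatter as either oxygen-bearing group. Nothing at hand explains this result. Still open, going by these compounds, is whether an amine or a longer chain here would give a step beyond the scatter. Changes to the methoxy group or the shared core also remain open.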